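A few compounds are considered here, and "the series" means these few. Any claim that something is new, unique, unknown or untested is made for them only; others in the source may bear on it.

Going by the values given here, in an assay for inhibition of Maternal embryonic leucine zipper kinase (Homo sapiens), read by ADP-Glo, with a stated time of 0.5 h (a higher number here means a weaker inhibitor, a lower number a stronger inhibitor), compound 1 `CC(C)Nc1sc(C(=O)c2ccc(Cl)s2)c(N)c1C#N` gives 192 nM; the only other number recorded, for compound 2 `CC(C)Nc1sc(C(=O)c2ccc(I)s2)c(N)c1C#N`, is 112 nM, within the scatter of it. Compound 3 `CC(C)Nc1sc(C(=O)c2ccc(Cl)s2)cc1C#N` returns only a limit of this assay, > 5000 nM. The two measured steps from compound 1 differ sharply in size: a 1.7-fold lower number from compound 1 to compound 2 (0.23 log units; within the scatter), whereas an at least 26-fold higher number from compound 1 to compound 3 (1.41 log units; beyond the scatter), a step ending at the limit of > 5000 nM in this assay, at which 1 of the 3 values shown sits. Compound 4 `CC(C)Nc1sc(C(=O)c2ccc(Cl)s2)c(N)c1C(N)=O` differs from compound 1 by carbamoyl in place of cyano on an aromatic carbon. Neither measured step touches this group, so neither bears directly on the change; the amino group alone has proved indispensable, while the halogen swap barely moved the number. A modest step upward is therefore expected, a 2.1-fold higher number from compound 1 to compound 4 (0.32 log units; beyond the scatter). Compound 4 is estimated at 400 nM, between 100 nM and 2000 nM.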

Compound 4, half-maximal inhibitory concentration: 388 nM
Estimate against measurement, compound 4: 1.0-fold (0.01 log units) above; the measured number falls inside the stated range.
By their numbers in this assay, from the lowest: compounds 2 and 1 (each within the scatter of the next); then compound 4. At a limit, above all of these: compound 3.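

At the position next to the ring atom that bears an amino group, the cyano group can give way to carbamoyl, which brings a hydrogen-bond donor, at a limited cost in this assay: a 2.0-fold higher number from compound 1 to compound 4 (0.31 log units; beyond the scatter). So the cyano group itself is not essential to a measurable number at this position. Nothing measured here accounts for the size of this step. Going by these compounds, whether a carboxylic acid or a methyl ester would fare similarly at this position remains open. So does whether carbamoyl would give the same step alongside iodo in place of chloro.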